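A few compounds are considered here, and "the series" means these few. Any claim that something is new, unique, unknown or untested is made for them only; others in the source may bear on it.

Compound 3 `CCCn1c(=O)c2nc(-c3nn[nH]n3)[nH]c2n(CCC)c1=O` stands, in an assay on cell membranes for binding affinity to adenosine receptor A1 (Cavia porcellus), read by radioligand binding (a lower number here means a stronger inhibitor, a higher number a weaker inhibitor), at the edge of what the measurement can report: compound 3 gives > 10000 nM, which is a limit of the assay and not a number, the point marked by the limit of > 10000 nM in this assay, at which 1 of the 3 values shown sits. The other measured compounds give numbers: in this assay compound 1 `CCCn1c(=O)c2nc([C@H]3CC4C=CC3C4)[nH]c2n(CCC)c1=O` gives 3.4 nM, and compound 2 `CC(C)(C)CNc1ncnc2c1ncn2C1O[C@H](CO)[C@@H](O)[C@H]1O` gives 17 nM. Among the measured compounds shown here, the one measured step that bears on the change ahead is an at least 2900-fold higher number from compound 1 to compound 3 (3.46 log units; beyond the scatter), and its size is known only as a lower bound. Compound 4 `CCCn1c(=O)c2nc(C(C)(C)C)[nH]c2n(CCC)c1=O` differs from compound 3 by tert-butyl in place of 2H-tetrazol-5-yl on an aromatic carbon. The entering tert-butyl, like the group of 7 carbon in compound 1, is built of carbon only, so the step is expected to run back toward the number of compound 1, large and in the direction of a lower number, though the group is smaller. Compound 4 is therefore expected in this assay at 15 nM, within 4 nM to 60 nM, an estimated at least 660-fold lower number from compound 3 to compound 4 (2.82 log units; beyond the scatter).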

Compound 4, inhibition constant: 31 nM
For compound 4 the middle estimate is 2.1-fold (0.32 log units) below the measured one; the measured number falls inside the stated range.
By their numbers in this assay, from the lowest: compound 1; then compounds 2 and 4 (each within the scatter of the next). At a limit, above all of these: compound 3.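

In this assay, among the compounds shown here, tert-butyl in place of 2H-tetrazol-5-yl on this aromatic carbon gives an at least 320-fold lower number from compound 3 to compound 4 (2.50 log units; beyond the scatter), so the position yields a real number with a group of carbon only that has no ring. The group of 7 carbon with its two rings is therefore not needed for a measurable number, yet it still counts, since the change to tert-butyl gives a 9.1-fold higher number from compound 1 to compound 4 (0.96 log units; beyond the scatter). Compound 3 stays a limit of the assay and not a number, so the size of its step is only a bound: the limit of > 10000 nM in this assay, at which 1 of the 4 values shown sits.

On these data alone, whether a single cyclopentyl ring or a longer chain such as n-butyl would fall nearer compound 1 or compound 4 remains open. So does where a carboxylic acid or an amine would stand at this carbon, since leaving tetrazole and entering tert-butyl differ in several counted features at once.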